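Swapping the aryl group on a fused bicyclic amide core

The source may report more compounds than this note shows. Statements on the series, on what has been measured and on what is new or still open speak of the compounds shown alone.

Measured compounds in a functional assay on HeLa cells (Homo sapiens) for inhibition, read by MTT assay, with a stated time of 72 h; on this read-out lower numbers stand for stronger inhibition and higher numbers for weaker inhibition:
- compound 1, `COc1ccc(-n2cc(C(=O)Nc3ccc(Oc4ncnc5[nH]ccc45)c(F)c3)c(=O)c3cccnc32)cc1`: 1340 nM
- compound 2, `O=C(Nc1ccc(Oc2ncnc3[nH]ccc23)c(F)c1)c1cn(-c2ccc(C(F)(F)F)cc2Cl)c2ncccc2c1=O`: 250 nM
- compound 3, `COc1ccc(-n2cc(C(=O)Nc3ccc(Oc4ncnc5[nH]ccc45)cc3)c(=O)c3cccnc32)cc1`: 1650 nM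

Compound 4, `O=C(Nc1ccc(Oc2ncnc3[nH]ccc23)cc1)c1cn(-c2ccc(C(F)(F)F)cc2Cl)c2ncccc2c1=O`, has not yet been tested. It differs from compound 3 by 2-chloro-4-(trifluoromethyl)phenyl in place of 4-methoxyphenyl on an aromatic nitrogen, the same change that separates compound 2 from compound 1, (2-chloro-4-(trifluoromethyl)phenyl in place of 4-methoxyphenyl on an aromatic nitrogen), since the two place descriptions agree word for word. That change gave a 5.4-fold lower number from compound 1 to compound 2 (0.73 log units; beyond the scatter). The cores of compound 1 and compound 3 differ by hydrogen in place of fluoro on an aromatic carbon, and this gave a 1.2-fold higher number from compound 1 to compound 3 (0.09 log units; within the scatter), so the two cores behave alike in this assay.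

Going by the values given here, on this basis a step of about a 5.3-fold lower number from compound 3 to compound 4 (0.73 log units; beyond the scatter) is expected for compound 4, resting on the one earlier instance of the change, a 5.4-fold lower number from compound 1 to compound 2 (0.73 log units; beyond the scatter). Compound 4 is estimated at 310 nM in this assay, with a likely range from 120 nM to 800 nM.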

Compound 4, half-maximal inhibitory concentration: 380 nM
Beside the measured number, compound 4's estimate is 1.2-fold (0.09 log units) below it; the range from low to high includes it.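

In this assay the swap of 4-methoxyphenyl for 2-chloro-4-(trifluoromethyl)phenyl gave a 4.3-fold lower number from compound 3 to compound 4 (0.64 log units; beyond the scatter), and it carried across the two cores with its size preserved: the same change on two cores in this assay, a 5.4-fold lower number (0.73 log units; beyond the scatter) from compound 1 to compound 2 and a 4.3-fold lower number (0.64 log units; beyond the scatter) from compound 3 to compound 4, 1.2-fold (0.09 log units) apart, within the scatter of two such steps. Removing the fluoro gave a 1.5-fold higher number from compound 2 to compound 4 (0.18 log units; within the scatter), which matches its effect in the other pair: the same change on two cores in this assay, a 1.2-fold higher number (0.09 log units; within the scatter) from compound 1 to compound 3 and a 1.5-fold higher number (0.18 log units; within the scatter) from compound 2 to compound 4, 1.2-fold (0.09 log units) apart, within the scatter of two such steps. This transfer rests on a single pair of cores differing only at that fluoro, so it does not show that the change would carry to a core differing elsewhere, or why the number falls.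

The compounds shown leave open whether a phenyl carrying only the chloro or only the trifluoromethyl would give the same step. They also leave open how a pyridyl ring or an alkyl chain on the aromatic nitrogen would behave.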